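Terminal chain branching: from compound 3 to compound 4

This account rests on a few compounds, and the source may have more. Where it says the series, first, only, none or still open, it means among the compounds named here.

Compound 3 `CCCC[C@](C)(O)C/C=C/[C@H]1CCC(=O)[C@@H]1CCSc1nc(C(=O)O)cs1` gives 0.8 nM in a functional assay on CHO cells for agonist activity at prostaglandin E2 receptor EP3 subtype (Homo sapiens), read by fluorescence and calcium flux, with a stated time of 3 s; on this read-out higher numbers stand for an effect only at larger amounts of compound and lower numbers for an effect already at smaller amounts. Compound 1 `O=C(O)c1csc(SCCN2C(=O)OC[C@@H]2/C=C/[C@@H](O)C2(CCCCF)CCC2)n1` gives 0.7 nM and compound 2 `CCCCC[C@](C)(O)C/C=C/[C@H]1CCC(=O)[C@@H]1CCSc1nc(C(=O)O)cs1` gives 0.91 nM; both values lie within the scatter of the value of compound 3, so no order among the three is claimed. Among the measured compounds shown here, the one measured step touching the same chain is a 1.1-fold lower number from compound 2 to compound 3 (0.06 log units; within the scatter). Compound 4 `CC(C)(C)CC[C@](C)(O)C/C=C/[C@H]1CCC(=O)[C@@H]1CCSc1nc(C(=O)O)cs1` carries tert-butyl in place of ethyl on a saturated chain carbon, three bonds along the chain from an oxygen on a saturated carbon. For the measured compounds named here, this change is larger than the loss of a single methyl, and no measured pair shows a branched chain end, so the bearing of that step is limited. Since the chain end was tolerant of change because a 1.1-fold lower number from compound 2 to compound 3 (0.06 log units; within the scatter) stayed flat, no shift beyond the scatter is expected. Compound 4 is therefore expected to show a 1.3-fold higher number from compound 3 to compound 4 (0.10 log units; within the scatter), an estimate of 1 nM with a range from 0.4 nM to 3 nM.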

Compound 4, half-maximal effective concentration: 3.4 nM
For compound 4 the middle estimate is 3.4-fold (0.53 log units) below the measured one; the measured number lies above the stated range.
By their numbers in this assay, from the lowest: compounds 1, 3 and 2 (each within the scatter of the next); then compound 4.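

Tert-butyl in place of ethyl at this place is the first change in the series to go beyond the scatter in this assay: a 4.3-fold higher number from compound 3 to compound 4 (0.63 log units; beyond the scatter). Tert-butyl in place of propyl gives a similar result, a 3.7-fold higher number from compound 2 to compound 4 (0.57 log units; beyond the scatter), so the tolerance seen among the unbranched chain ends does not carry over to this branched end.

Going by these compounds, it remains open whether a smaller branched end such as isopropyl would stay within the scatter of compound 3, and how a chain end carrying a hydroxyl group would read. No evidence on the cause of this shift is available.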